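The source may report more compounds than this note shows. Statements on the series, on what has been measured and on what is new or still open speak of the compounds shown alone.

Measured in an assay on LM cells for displacement of a labelled ligand from Neuropeptide Y receptor type 5 (Homo sapiens); a higher number here means a weaker inhibitor, a lower number a stronger inhibitor:
Compound 1 `Fc1ccc(C2(c3ccc(F)cc3)CNC(c3cccc(Cl)c3)=N2)cc1`, 5.4 nM
Compound 2 `Fc1ccc(C2(c3ccc(F)cc3)CNC(c3cccc(Br)c3)=N2)cc1`, 4.8 nM
Compound 3 `Fc1ccc(C2(c3ccc(F)cc3)CNC(c3cccs3)=N2)cc1`, 54 nM

Compound 3 gives the highest of the three numbers, with a 10-fold higher number from compound 1 to compound 3 (1.00 log units; beyond the scatter) and an 11-fold higher number from compound 2 to compound 3 (1.05 log units; beyond the scatter) separating it from the two halophenyl analogues, which sit together (a 1.1-fold lower number from compound 1 to compound 2 (0.05 log units; within the scatter)). Compound 4 `Fc1ccc(C2(c3ccc(F)cc3)CNC(c3cccnc3)=N2)cc1` differs from compound 3 by pyridin-3-yl in place of thiophen-2-yl on a carbon with a double bond to nitrogen. Going by the values given here, no measured step exchanges one heteroaryl ring for another; the two steps that bear on this position both show that leaving the thiophen-2-yl ring for a six-membered aromatic ring gave a markedly lower number. A six-membered ring without a halogen is expected to recover part of that, so compound 4 is estimated at 30 nM (range 8 nM to 120 nM), a step of a 1.8-fold lower number from compound 3 to compound 4 (0.26 log units; within the scatter) that is expected to fall short of the full halophenyl gain.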

Compound 4, half-maximal inhibitory concentration: 7.2 nM
Estimate against measurement, compound 4: 4.2-fold (0.62 log units) above; measured number outside the range, below it.
By their numbers in this assay, from the lowest: compounds 2, 1 and 4 (each within the scatter of the next); then compound 3.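

The exchange of thiophen-2-yl for pyridin-3-yl (a 7.5-fold lower number from compound 3 to compound 4 (0.88 log units; beyond the scatter)) shows that a six-membered aromatic ring at this position needs no halogen to reach the level of the halophenyl analogues, as the steps to compound 4 (a 1.5-fold higher number from compound 2 to compound 4 (0.18 log units; within the scatter); a 1.3-fold higher number from compound 1 to compound 4 (0.12 log units; within the scatter)) both stay within the scatter. Among these four compounds, only compound 3 stands apart. Nothing available here explains this difference.

On these data alone, it remains open whether an unsubstituted phenyl ring would match these compounds, and whether an amine on the pyridin-3-yl ring would keep the number at this level.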